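Lengthening the alkyl chain on the shared core

The compounds below may be only part of what the source reports. "The series", "measured", "known", "first", "only" and "open" are said of these compounds alone.

Going by the values given here, in a functional assay on MCF7 cells (Homo sapiens) for antiproliferative activity, read by MTT assay, with a stated time of 48 h (a lower number here means a stronger inhibitor, a higher number a weaker inhibitor), compound 1 `CCCCCCCCCCn1cc(COC[C@@H]2OC[C@H](N)[C@H]2O)nn1` gives 45000 nM and compound 2 `CCCCCCCCCCCCCCCCn1cc(COC[C@@H]2OC[C@H](N)[C@H]2O)nn1` gives 2260 nM, the lower of the two numbers so far. Compound 3 `CCCCCCCCCCCCCCCCCCn1cc(COC[C@@H]2OC[C@H](N)[C@H]2O)nn1` keeps the shared core and differs from compound 2 in the chain: ethyl in place of hydrogen on a saturated chain carbon, ten or more bonds along the chain from an aromatic nitrogen. Among the compounds with values here, one measured step bears on this change, hexyl in place of hydrogen at the same kind of place, and it was large: a 20-fold lower number from compound 1 to compound 2 (1.30 log units; beyond the scatter). Ethyl is the smaller addition, so a smaller step in the same direction is expected, possibly within the scatter, although a single step cannot show whether the trend continues. The expected change is a 1.6-fold lower number from compound 2 to compound 3 (0.21 log units; within the scatter). In this assay, compound 3 is estimated at 1400 nM, with an expected range of 500 nM to 5000 nM.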

Compound 3, half-maximal inhibitory concentration: 1930 nM
Beside the measured number, compound 3's estimate is 1.4-fold (0.14 log units) below it; low and high end bracket the measured number.
By their numbers in this assay, from the lowest: compounds 3 and 2 (each within the scatter of the next); then compound 1.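

In this assay, ethyl in place of hydrogen on a saturated chain carbon, ten or more bonds along the chain from an aromatic nitrogen, gives a 1.2-fold lower number from compound 2 to compound 3 (0.07 log units; within the scatter) and so does not repeat the large step seen earlier at this kind of place. Octyl in place of hydrogen gives a 23-fold lower number from compound 1 to compound 3 (1.37 log units; beyond the scatter) and is of similar size to the earlier step to compound 2, so among these three compounds the large difference separates compound 1 from the other two, while compound 2 and compound 3 cannot be told apart. No measured evidence here bears on why the numbers level off.

As far as these compounds go, whether a longer chain than that of compound 3 would stay level or shift the number remains open. From the compounds shown here alone, how a carboxylic acid in place of the chain would read on the shared core also remains open.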